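The source may report more compounds than this note shows. Statements on the series, on what has been measured and on what is new or still open speak of the compounds shown alone.

Measured so far:
compound 1 `COc1cc(/C=C/C(=O)C2=C(/C=C/c3ccc(O)c(OC)c3)NC(=O)NC2c2c(Cl)cccc2Cl)ccc1O` — 44.2%
compound 2 `COc1cc(/C=C/C(=O)C2=C(/C=C/c3ccc(O)c(OC)c3)NC(=O)NC2c2ccccc2Cl)ccc1O` — 56%
compound 3 `COc1cc(/C=C/C(=O)C2=C(/C=C/c3ccc(O)c(OC)c3)NC(=S)NC2c2ccccc2)ccc1O` — 50.4%

In a functional assay, with a stated time of 20 min, tested at 50 uM (a lower number here means a weaker effect, a higher number a stronger effect of the compound at the concentration tested), compound 3 lies close to the other two: its value sits within the usual scatter of compound 2 and of compound 1, so no ordering among the three can be read from it. Compound 4 `COc1cc(/C=C/C(=O)C2=C(/C=C/c3ccc(O)c(OC)c3)NC(=S)NC2c2ccc(C)cc2)ccc1O` differs from compound 3 by one change, (methyl in place of hydrogen on an aromatic carbon). The only measured step among these compounds, a number 11.8 percentage points higher from compound 1 to compound 2 (beyond the scatter), concerns the removal of a chloro group on a different ring and does not involve a methyl, so it offers no direct guide. With nothing pointing to a change, the step of a number 0.4 percentage points lower from compound 3 to compound 4 (within the scatter) is expected to stay within the scatter, and compound 4 is estimated at 50%, between 36% and 64%.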

Compound 4, a percentage reported as activity, at one concentration (the size of the read-out at that concentration, not a potency): 41%
Compound 4: the middle estimate sits 9 percentage points above what was measured; the measured number falls inside the stated range.
By their numbers in this assay, from the lowest: compounds 4, 1, 3 and 2 (each within the scatter of the next, the first and the last beyond it).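

In this assay, going from phenyl to 4-methylphenyl gives a number 9.4 percentage points lower from compound 3 to compound 4 (within the scatter), so a single methyl at this place on the aromatic ring does not clearly separate the two compounds. Among these compounds, this is the only reading at this position, and it shows no effect of the methyl that stands out from the usual scatter. No measurement shown here offers any explanation of this step. As far as these compounds go, whether an amine or a carboxylic acid on the same aromatic carbon would move the number beyond the scatter remains open.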